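A Phenyl Swap on the Shared Core

This account rests on a few compounds, and the source may have more. Where it says the series, first, only, none or still open, it means among the compounds named here.

Of the compounds shown here, three on the shared core have been tested in a functional assay on MGC-803 cells (Homo sapiens) for cytotoxicity, read by MTT assay, with a stated time of 72 h; a higher number here means a weaker inhibitor, a lower number a stronger inhibitor. Compound 1, `CCCCCCCCCCCCNc1nc(SCc2ccc(C(F)(F)F)cc2)nc2ccccc12`, gives only the limit > 50000 nM. Compound 2, `CCCCCCCCCCCCCCNc1nc(SCc2ccc(C(F)(F)F)cc2)nc2ccccc12`, likewise gives only the limit > 50000 nM. Their step that the two limits leave unreadable from compound 1 to compound 2 cannot be read because of the limit of > 50000 nM in this assay, at which 2 of the 3 values shown sit. Among the compounds with values here, compound 3, `FC(F)(F)c1ccc(CSc2nc(Nc3cccc(C(F)(F)F)c3)c3ccccc3n2)cc1`, is the one compound with a number: in this assay compound 3 gives 15100 nM. It is the only number shown for the three. Compound 4, `CCOc1ccc(Nc2nc(SCc3ccc(C(F)(F)F)cc3)nc3ccccc23)cc1`, differs from compound 3 by 4-ethoxyphenyl in place of 3-(trifluoromethyl)phenyl on a nitrogen on an aromatic ring. Within the data shown here, no measured step touches a change on this nitrogen; the one measured step concerns the chain and is unreadable. With nothing to guide it, the expected step of a 1.0-fold lower number from compound 3 to compound 4 (0.00 log units; within the scatter) is none beyond the scatter. Compound 4 is therefore estimated at 15000 nM, within 5000 nM to 50000 nM.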

Compound 4, half-maximal inhibitory concentration: 37000 nM
For compound 4 the middle estimate is 2.5-fold (0.39 log units) below the measured one, within the range that was stated.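

In this assay, within the data shown here, the swap gives a 2.5-fold higher number from compound 3 to compound 4 (0.39 log units; beyond the scatter), the first readable change on this nitrogen; the one earlier step concerned the chain and could not be read. It shows that the group on this nitrogen can shift the number beyond the scatter, if only modestly, with compound 4 the weaker of the two. Nothing shown accounts for the direction of this step. The two groups differ in both substituent and ring position, so this single step cannot separate those changes. As far as these compounds go, how a plain phenyl or a benzyl group on this nitrogen would compare remains open.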